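The source may report more compounds than this note shows. Statements on the series, on what has been measured and on what is new or still open speak of the compounds shown alone.

Working notes on the series. In a functional assay on CAKI-1 cells (Homo sapiens) for inhibition, read by sulforhodamine B assay, with a stated time of 48 h (a lower number here means a stronger inhibitor of growth, a higher number a weaker inhibitor of growth), compound 1 `O=C(Nc1cccc(-n2cc(-c3ccncc3)c(-c3ccc(Cl)c(O)c3)n2)c1)Nc1ccc(Cl)c(Cl)c1` gives 1110 nM; among the three numbers at hand this is the second highest, within the scatter of compound 3 and separated only from compound 2. Compound 2 `COc1cc(-c2nn(-c3cccc(NC(=O)c4ccc(Cl)c(C(F)(F)F)c4)c3)cc2-c2ccncc2)ccc1Cl` gives 2300 nM, and compound 3 `COc1cc(-c2nn(-c3cccc(NC(=O)Nc4cccc(C(F)(F)F)c4)c3)cc2-c2ccncc2)ccc1Cl` gives 1030 nM. Among the compounds with values here, the single step recorded between measured compounds, a 2.2-fold lower number from compound 2 to compound 3 (0.35 log units; beyond the scatter), is modest and concerns a different change of the amide side chain on a different core, so it does not speak directly to the step taken here.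

Compound 4 `O=C(Nc1cccc(-n2cc(-c3ccncc3)c(-c3ccc(Cl)c(O)c3)n2)c1)Nc1ccc(Cl)c(C(F)(F)F)c1` differs from compound 1 by trifluoromethyl in place of chloro on an aromatic carbon. Within the data shown here, no measured pair isolates this exchange of chloro for trifluoromethyl on the shared core of compound 1; compounds 2 and 3 carry a trifluoromethyl already, but on the methoxy core, and neither is paired against a chloro analogue. With nothing to lean on, the expected movement in this assay is none beyond the scatter, a 1.1-fold lower number from compound 1 to compound 4 (0.05 log units; within the scatter). Compound 4 is therefore estimated at 1000 nM, with a range from 450 nM to 2400 nM.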

Compound 4, concentration for 50% growth inhibition: 795 nM
Estimate against measurement, compound 4: 1.3-fold (0.10 log units) above, within the range that was stated.
By their numbers in this assay, from the lowest: compounds 4, 3 and 1 (each within the scatter of the next); then compound 2.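

The exchange of chloro for trifluoromethyl on this aromatic carbon, ortho to a chloro group and meta to a large group, reads in this assay as a 1.4-fold lower number from compound 1 to compound 4 (0.14 log units; within the scatter) and so stays within the scatter. Within the data shown here, this is the first pair that isolates the change on the shared core, and it shows that at this position trifluoromethyl and chloro cannot be told apart in this read-out. No measurement of any other kind is at hand that bears on this result.

Open, as far as these compounds go, is whether a different group on this carbon, such as a nitrile, an amine or a carboxylic acid, would move the number beyond the scatter. Also open, from the compounds shown here alone, is whether the same exchange would read alike on the core of compound 3.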